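The compounds below may be only part of what the source reports. "The series", "measured", "known", "first", "only" and "open" are said of these compounds alone.

In a functional assay on brain (Rattus norvegicus, strain Wistar) for inhibition (on this read-out lower numbers stand for stronger inhibition and higher numbers for weaker inhibition), compound 1 (`Cc1ccc(-c2c(C)[nH]c(=O)n2C)cc1`) gives 85300 nM as its half-maximal value, compound 2 (`Cc1[nH]c(=O)n(C)c1-c1ccc(C(C)(C)C)cc1`) gives 8400 nM and compound 3 (`Cc1[nH]c(=O)n(C)c1-c1ccc(OCCC(C)C)cc1`) gives 6600 nM on the same scale. Compound 3 thus stands with compound 2 at the low end of these numbers, the two lying within the scatter of each other (a 1.3-fold lower number from compound 2 to compound 3 (0.10 log units; within the scatter)) and well under compound 1 (a 13-fold lower number from compound 1 to compound 3 (1.11 log units; beyond the scatter)). Compound 4 (`Cc1[nH]c(=O)n(C)c1-c1ccc(-c2ccccc2)cc1`) carries phenyl in place of isopentyloxy on an aromatic carbon. Going by the values given here, three measured steps bear on this change. Two are large and lead away from methyl at the same place (a 10-fold lower number from compound 1 to compound 2 (1.01 log units; beyond the scatter)) (a 13-fold lower number from compound 1 to compound 3 (1.11 log units; beyond the scatter)), while the swap from tert-butyl to isopentyloxy stays within the scatter (a 1.3-fold lower number from compound 2 to compound 3 (0.10 log units; within the scatter)). Among the compounds with values here, no compound with a ring at this place has been measured yet, so the range is kept wide. In this assay no shift beyond the scatter is expected, and the estimated step is a 1.1-fold higher number from compound 3 to compound 4 (0.03 log units; within the scatter) in size. For compound 4 the expected value is 7000 nM within an estimated range from 2500 nM to 20000 nM as the likely span.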

Compound 4, half-maximal inhibitory concentration: 6300 nM
The estimate for compound 4 lay 1.1-fold (0.05 log units) above the measured number, within the range that was stated.
By their numbers in this assay, from the lowest: compounds 4, 3 and 2 (each within the scatter of the next); then compound 1.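

In this assay, a ring at this place proves no different from the two groups without one: phenyl in place of isopentyloxy gives a 1.0-fold lower number from compound 3 to compound 4 (0.02 log units; within the scatter), and phenyl in place of tert-butyl gives a 1.3-fold lower number from compound 2 to compound 4 (0.12 log units; within the scatter), both within the scatter. The change also takes away the hydrogen-bond acceptor of isopentyloxy, and no shift beyond the scatter follows. Phenyl in place of methyl gives a 14-fold lower number from compound 1 to compound 4 (1.13 log units; beyond the scatter), so all three larger groups stand apart from methyl by a similar large step, while none stands apart from the others.

No supporting evidence is available to explain this result. Going by these compounds, it remains open whether an amine, a carboxylic acid or a longer chain on this aromatic carbon would shift the number beyond the scatter of these three compounds.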